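Taking one hydroxy off a weakly active compound

The compounds below may be only part of what the source reports. "The series", "measured", "known", "first", "only" and "open" are said of these compounds alone.

In a functional assay on A549 cells (Homo sapiens) for antiproliferative activity, read by MTT assay, with a stated time of 48 h (on this read-out higher numbers stand for weaker inhibition and lower numbers for stronger inhibition), compound 1 (`C=C(C(=O)O)[C@@H]1CC[C@@]2(C)CCC(=O)C(C)=C2C1`) gives > 100000 nM as a limit of the assay. Among the compounds with values here, compound 2 (`C=C(C(=O)O)[C@@H]1CC[C@]2(C)C(=C(C)C(=O)[C@@H](O)[C@H]2O)C1`) is the only one with an actual number so far, at 74000 nM on this read-out. Compound 3 (`C=C(C(=O)O)[C@@H]1CC[C@]2(C)C(=C(C)C(=O)C[C@H]2O)C1`) departs from compound 2 in one place (hydrogen in place of hydroxy on a saturated ring carbon): hydrogen in place of hydroxy on a saturated ring carbon. Within the data shown here, no measured step covers this change, so only a small shift towards weaker inhibition in this assay is expected, perhaps none beyond the scatter. The estimated step of a 1.1-fold higher number from compound 2 to compound 3 (0.06 log units; within the scatter) is accordingly modest. Compound 3 is expected at 85000 nM within an estimated range from 35000 nM to 170000 nM in all.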

Compound 3, half-maximal inhibitory concentration: > 100000 nM
Compound 3: no number, only a limit; the forecaster's own chance of this, stated with the estimate: 40%; middle value at least 1.1-fold (0.07 log units) from the limit.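

Hydrogen in place of hydroxy on this saturated ring carbon gives an at least 1.3-fold higher number from compound 2 to compound 3 (0.13 log units; that floor lies within the scatter) in this assay. From the compounds shown here alone, compound 3 gives > 100000 nM, which is a limit of the assay, so the full size of the step stays unknown. With this change, compound 2 remains the only one of the three with an actual number: the limit of > 100000 nM in this assay, at which 2 of the 3 values shown sit.

The step between compound 1 and compound 3 cannot be read. Going by these compounds, whether a methoxy group or an amine on this same ring carbon would give a measurable number in this assay remains open.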